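Working notes: from compound 2 to compound 3

The source may report more compounds than this note shows. Statements on the series, on what has been measured and on what is new or still open speak of the compounds shown alone.

Measured so far:
compound 1, `Cc1n[nH]cc1-c1cc2nc(C3CCCCC3)[nH]c(=O)c2s1`: 940 nM
compound 2, `Cc1n[nH]cc1-c1cc2nc(-c3ccccc3)[nH]c(=O)c2s1`: 1600 nM

In an assay for inhibition of Rho-associated protein kinase 1 (Homo sapiens), read by TR-FRET, with stated times of 5 min and 2 h (on this read-out higher numbers stand for weaker inhibition and lower numbers for stronger inhibition), compound 1 gives 940 nM, and compound 2 gives 1600 nM. The only step available is a 1.7-fold higher number from compound 1 to compound 2 (0.23 log units; within the scatter), so on the numbers shown compound 2 is not separated from compound 1; the two values are as good as equal.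

The next compound, compound 3 `CCOCc1nc2cc(-c3c[nH]nc3C)sc2c(=O)[nH]1`, is made from compound 2 by a single change: ethoxymethyl in place of phenyl on an aromatic carbon. Within the data shown here, the one measured step, from compound 1 to compound 2, exchanges one ring for another at the same place and does not touch an ethoxymethyl or any open chain, so it bears on the present change only loosely; it shows that at this place a change of group can pass without a step beyond the scatter. Among the measured compounds shown here, no measured step speaks for or against a chain here.

The expectation for compound 3 in this assay is therefore no step beyond the scatter, a 1.3-fold higher number from compound 2 to compound 3 (0.10 log units; within the scatter). For compound 3 the estimate is 2000 nM, with a range from 700 nM to 6000 nM.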

Compound 3, half-maximal inhibitory concentration: 2100 nM
The estimate for compound 3 lay 1.1-fold (0.02 log units) below the measured number; measured number inside the range.
By their numbers in this assay, from the lowest: compounds 1, 2 and 3 (each within the scatter of the next, the first and the last beyond it).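

In this assay, among these compounds, this place, the aromatic carbon between two ring nitrogen atoms, now carries an open chain for the first time, and ethoxymethyl in place of phenyl gives a 1.3-fold higher number from compound 2 to compound 3 (0.12 log units; within the scatter) with no separation of the two compounds, so at this place the six-membered aromatic ring of carbon only can give way to a chain with no step beyond the scatter. Ethoxymethyl in place of cyclohexyl gives a 2.2-fold higher number from compound 1 to compound 3 (0.35 log units; beyond the scatter) and is the first step in the series to pass the scatter, though only modestly, while phenyl stays within the scatter of both other groups, so the three compounds show only a shallow spread at this place. Nothing shown accounts for either step.

Open, from the compounds shown here alone, is how a propyl chain, a longer ether chain, an amine or a carboxylic acid at this place would read in this assay, and with them whether the oxygen of ethoxymethyl has any part in the value. Also open, going by these compounds, is whether the same shallow spread would hold with any other group on the rest of the shared core.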